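The source may hold more compounds than are shown below. What is called first, only, known or untested is meant among the compounds shown, and "the series" means these compounds.

Compound 1 `CC(C)(C)c1ccc(C(=O)N2CCC3(CC2)C(=O)N(CC(=O)NCCN)CN3c2ccccc2)cc1`: 7000 nM
Compound 2 `CC(C)(C)c1ccc(C(=O)N2CCC3(CC2)C(=O)N(CC(=O)NCCCCCNS(C)(=O)=O)CN3c2ccccc2)cc1`: 5500 nM
Compound 3 `CC(C)(C)c1ccc(C(=O)N2CCC3(CC2)C(=O)N(CC(=O)N2CCC(O)CC2)CN3c2ccccc2)cc1`: 4700 nM

These three compounds share one core and differ only in the group on a carbonyl carbon. In an assay on HEK293 cells for displacement of a labelled ligand from NPC1-like intracellular cholesterol transporter 1 (Homo sapiens) (on this read-out higher numbers stand for weaker inhibition and lower numbers for stronger inhibition), compound 3 gives the smallest of the three numbers, yet the steps of a 1.5-fold lower number from compound 1 to compound 3 (0.17 log units; within the scatter) and a 1.2-fold lower number from compound 2 to compound 3 (0.07 log units; within the scatter) both stay within the scatter, so the three cannot really be told apart. Compound 4 `CC(C)(C)c1ccc(C(=O)N2CCC3(CC2)C(=O)N(CC(=O)NCCCN)CN3c2ccccc2)cc1` carries (3-aminopropyl)amino in place of 4-hydroxypiperidin-1-yl on a carbonyl carbon. The closest comparison is compound 1, whose (2-aminoethyl)amino group is a near relative of the entering group, and the step of a 1.5-fold lower number from compound 1 to compound 3 (0.17 log units; within the scatter) lay within the scatter, as did a 1.2-fold lower number from compound 2 to compound 3 (0.07 log units; within the scatter). No step beyond the scatter is therefore expected in this assay for compound 4 a 1.3-fold higher number from compound 3 to compound 4 (0.11 log units; within the scatter). Compound 4 is estimated at 6000 nM, between 3000 nM and 12000 nM.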

Compound 4, half-maximal inhibitory concentration: 4200 nM
For compound 4 the middle estimate is 1.4-fold (0.15 log units) above the measured one; low and high end bracket the measured number.
By their numbers in this assay, from the lowest: compounds 4, 3, 2 and 1 (each within the scatter of the next).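

Replacing the ring of compound 3 with the open (3-aminopropyl)amino chain at this carbonyl carbon gives a 1.1-fold lower number from compound 3 to compound 4 (0.05 log units; within the scatter) in this assay and so shows that a ring is not needed here for a number in this range. The open-chain comparisons agree, with a 1.3-fold lower number from compound 2 to compound 4 (0.12 log units; within the scatter) and a 1.7-fold lower number from compound 1 to compound 4 (0.22 log units; within the scatter) as the steps, so all four groups remain indistinguishable. No measurement shown explains this flat result.

As far as these compounds go, whether a carboxylic acid or a much longer chain ending in an amine at this carbonyl carbon would give a step beyond the scatter remains open.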